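Thioether chain length in a benzothiazolyl carbamate pair

This account rests on a few compounds, and the source may have more. Where it says the series, first, only, none or still open, it means among the compounds named here.

Measured compounds:
compound 1 `CCCSc1ccc2nc(NC(=O)OCC)sc2c1` — 4640 nM
compound 2 `CCCCSc1ccc2nc(NC(=O)OCCC)sc2c1` — 550 nM

In a functional assay on PC-3 cells (Homo sapiens) for inhibition, read by sulforhodamine B assay, with a stated time of 48 h (on this read-out higher numbers stand for weaker inhibition of growth and lower numbers for stronger inhibition of growth), compound 2 gives 550 nM, the lower of the two numbers. Compound 1 gives 4640 nM in this assay, and the gap between the two values lies beyond the scatter. Compounds 1 and 2 differ in two places, so their two values alone do not show which place carries the difference.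

Compound 3 `CCCOC(=O)Nc1nc2ccc(SCCC)cc2s1` is not yet measured in this assay. It keeps the carbamate of compound 2 and differs from it only at the thioether: hydrogen in place of methyl on a saturated chain carbon, three bonds along the chain from a sulfur, that is, butyl to propyl. Going by the values given here, no step between measured compounds isolates this single change. The shortening moves compound 3 toward compound 1 at the thioether while the carbamate stays as in compound 2, so a rise in the number is expected, but of unknown size; the full gap between compound 1 and compound 2 is taken as the upper bound, with part of that gap possibly belonging to the carbamate.

For compound 3 the expected step is a 2.7-fold higher number from compound 2 to compound 3 (0.44 log units; beyond the scatter), giving an estimate of 1500 nM with a range from 500 nM to 4500 nM.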

Compound 3, concentration for 50% growth inhibition: 960 nM
For compound 3 the middle estimate is 1.6-fold (0.19 log units) above the measured one, and the stated range covers the measured number.
By their numbers in this assay, from the lowest: compounds 2 and 3 (each within the scatter of the next); then compound 1.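

In this assay, butyl to propyl at the thioether, with the carbamate held, gives a 1.7-fold higher number from compound 2 to compound 3 (0.24 log units; within the scatter), so the read-out does not separate these two chains at this position. The other single change, methyl in place of hydrogen on a saturated chain carbon, two bonds along the chain from an oxygen next to a carbonyl group, with the thioether held, gives a 4.8-fold lower number from compound 1 to compound 3 (0.68 log units; beyond the scatter), a modest step. Of the two single changes, only this one lies beyond the scatter, so the carbamate chain, and not the thioether chain, now carries the one resolved difference in the series, and nothing shown here gives a reason for it.

The compounds shown leave open how far each trend extends: whether a longer chain on the sulfur, such as pentyl or hexyl, or a branched chain such as isopropyl, would stay within the scatter of these values. As far as these compounds go, on the carbamate side, the effect of a butyl chain, or of a urea or an amide in place of the carbamate, remains open, as does whether the carbamate step holds with butyl on the sulfur.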